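Swapping ethyl for chloro on an aromatic carbon

The source may report more compounds than this note shows. Statements on the series, on what has been measured and on what is new or still open speak of the compounds shown alone.

In a functional assay on MCF7 cells (Homo sapiens) for antiproliferative activity, read by sulforhodamine B assay, with a stated time of 48 h (a higher number here means a weaker inhibitor, a lower number a stronger inhibitor), compound 1 `O=C1NCCN1c1ccc(S(=O)(=O)Nc2ccc(F)cc2)cc1` gives 690 nM and compound 2 `O=C1NCCN1c1ccc(S(=O)(=O)Nc2ccccc2)cc1` gives 470 nM while compound 3 `CCc1cccc(NS(=O)(=O)c2ccc(N3CCNC3=O)cc2)c1` gives 130 nM as the lowest number of the three, which makes it the strongest inhibitor here. Hydrogen in place of fluoro gives a 1.5-fold lower number from compound 1 to compound 2 (0.17 log units; within the scatter) so that change tells little. Ethyl in place of hydrogen gives a 3.6-fold lower number from compound 2 to compound 3 (0.56 log units; beyond the scatter) and the change from 4-fluorophenyl to 3-ethylphenyl gives a 5.3-fold lower number from compound 1 to compound 3 (0.72 log units; beyond the scatter) as the two clearer steps.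

Among the measured compounds shown here, compound 4 `O=C1NCCN1c1ccc(S(=O)(=O)Nc2cccc(Cl)c2)cc1` has chloro in place of ethyl on an aromatic carbon and no measured step makes this exact swap. The closest guide is a 3.6-fold lower number from compound 2 to compound 3 (0.56 log units; beyond the scatter) for a group added at this same place, and chloro still fills it. Part of that gain should therefore remain, so a small rise in this assay is expected, probably not beyond the scatter. The expected change is a 1.7-fold higher number from compound 3 to compound 4 (0.23 log units; within the scatter) on this estimate. The estimated value for compound 4 is 220 nM within an expected range of 90 nM to 480 nM for repeated measurements.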

Compound 4, half-maximal inhibitory concentration: 79 nM
Beside the measured number, compound 4's estimate is 2.8-fold (0.44 log units) above it; measured number outside the range, below it.
By their numbers in this assay, from the lowest: compounds 4 and 3 (each within the scatter of the next); then compounds 2 and 1 (each within the scatter of the next).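

In this assay, a 1.6-fold lower number from compound 3 to compound 4 (0.22 log units; within the scatter) leaves chloro and ethyl indistinguishable at this place, even though chloro has one heavy atom and ethyl has two. The gain over the unsubstituted ring is therefore not particular to ethyl, since chloro in place of hydrogen also gives a 5.9-fold lower number from compound 2 to compound 4 (0.77 log units; beyond the scatter) and stands clearly apart. The change from 4-fluorophenyl to 3-chlorophenyl gives an 8.7-fold lower number from compound 1 to compound 4 (0.94 log units; beyond the scatter) and widens the range of the series, but it alters two places on the ring at once and cannot be credited to either alone.

From the compounds shown here alone, whether an amine, a carboxylic acid or a longer chain at this place would keep the gain remains open. Nothing shown here explains why chloro and ethyl read alike in this assay.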